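The source may report more compounds than this note shows. Statements on the series, on what has been measured and on what is new or still open speak of the compounds shown alone.

Measured in a functional assay on NALM-6 cells (Homo sapiens) for cytotoxicity, read by MTT assay, with a stated time of 46 h; on this read-out higher numbers stand for weaker inhibition and lower numbers for stronger inhibition:
- compound 1 `O=C1/C(=C\c2ccncc2)C(c2ccccc2)Oc2ccccc21` gives 700 nM
- compound 2 `O=C1/C(=C\c2ccc(O)cc2)COc2ccccc21` gives 466000 nM
- compound 3 `N#Cc1ccc(Cc2coc3ccccc3c2=O)cc1` gives 4800 nM

In this assay, compound 3 at 4800 nM has the second highest of the three numbers. Compound 1 at 700 nM has a lower number and compound 2 at 466000 nM a higher one, and both gaps lie beyond the usual scatter.

Compound 4 `O=c1c(Cc2ccc(F)cc2)coc2ccccc12` keeps the core of compound 3 and changes one group: fluoro in place of cyano on an aromatic carbon. In words, this is fluoro in place of cyano on an aromatic carbon, para to a large group.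

Among the compounds with values here, no two measured compounds differ in just one place, so no measured step shows what such a swap does. The expectation therefore starts from compound 3 at 4800 nM and assumes that a single small swap moves the number little. No step beyond the scatter is expected in this assay, though the uncertainty is wide. The expected change is a 1.3-fold higher number from compound 3 to compound 4 (0.10 log units; within the scatter). For compound 4 the estimated value is 6000 nM, with an expected range from 1500 nM to 22000 nM.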

Compound 4, half-maximal inhibitory concentration in the NALM-6 assay: 8200 nM
Compound 4: the middle estimate sits 1.4-fold (0.14 log units) below what was measured, and the stated range covers the measured number.
By their numbers in the NALM-6 assay, from the lowest: compound 1; then compounds 3 and 4 (each within the scatter of the next); then compound 2.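

Within the data shown here, in the NALM-6 assay, this pair gives the first reading of a swap on this aromatic carbon, para to a large group, and fluoro in place of cyano gives a 1.7-fold higher number from compound 3 to compound 4 (0.23 log units; within the scatter). So in this assay, the swap does not separate the two compounds, even though the nitrile leaves and a single fluorine atom enters. In a physicochemical assay for lipophilicity, read by HPLC (on this read-out higher numbers stand for higher lipophilicity and lower numbers for lower lipophilicity), compound 3 gives 3.58 and compound 4 gives 4.02. For this one pair, higher lipophilicity therefore comes without a separation in the NALM-6 assay, as the physicochemical assay shows: the measured partition coefficient of compound 3, 3.58, and of compound 4, 4.02, a number 0.44 log units higher (beyond the scatter)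

Only these two groups are shown at this position, so it remains open whether an amine, a carboxylic acid or a longer chain there would move the number beyond the scatter. Compound 1 and compound 2 differ from this pair in more than one place, so they cannot show what this position contributes.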